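The compounds below may be only part of what the source reports. "The series", "measured", "known", "first", "only" and "open" are said of these compounds alone.

Compound 1 `C=C(Br)C(=O)Nc1cccc(-c2cn3nc(Cc4ccc(OC)cc4)sc3n2)c1` is the starting point of this set. In a functional assay on CCRF-CEM cells (Homo sapiens) for inhibition, read by cell counting, with a stated time of 3 days (a higher number here means a weaker inhibitor, a lower number a stronger inhibitor), compound 1 gives 2300 nM, the lowest of the two numbers recorded; the nearest is compound 2 `Nc1cccc(-c2cn3nc(CCc4ccccc4)sc3n2)c1`, which in this assay gives 30000 nM. Compound 3 `COc1ccc(Cc2nn3cc(-c4cccc(N)c4)nc3s2)cc1` yields in this assay only a limit, >= 250000 nM, and not a number.

Two measured steps frame the series. Replacing the (1-bromoethenyl)carbonyl with hydrogen on the aniline nitrogen gives an at least 100-fold higher number from compound 1 to compound 3 (2.03 log units; beyond the scatter). Exchanging the benzyl for 4-methoxyphenyl on the saturated chain carbon gives an at least 8.3-fold higher number from compound 2 to compound 3 (0.92 log units; beyond the scatter); this comparison rests on the boundary the limit of >= 250000 nM in this assay, at which 1 of the 3 values shown sits, and so records only a floor for its size.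

Compound 4 `C=C(Br)C(=O)Nc1cccc(-c2cn3nc(-c4ccc(CC)cc4)sc3n2)c1` keeps the (1-bromoethenyl)carbonyl of compound 1 and differs only at the tail: 4-ethylphenyl in place of 4-methoxybenzyl on an aromatic carbon. Within the data shown here, no measured pair tests this exact exchange. The step from compound 2 to compound 3 shows that the aryl tail can shift the number by an at least modest amount, but it was recorded in the amine series and in the opposite direction of substitution. A modest step is therefore expected, most likely toward a somewhat higher number or none beyond the scatter.

Compound 4 is expected to give 3500 nM in this assay, within 800 nM to 15000 nM, a step estimated as a 1.5-fold higher number from compound 1 to compound 4 (0.18 log units; within the scatter).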

Compound 4, half-maximal inhibitory concentration: 3400 nM
Compound 4: middle estimate off by 1.0-fold (0.01 log units), on the high side, within the range that was stated.
By their numbers in this assay, from the lowest: compounds 1 and 4 (each within the scatter of the next); then compound 2. At a limit, above all of these: compound 3.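

In this assay, the tail on the aromatic carbon of the five-membered ring can be exchanged with the (1-bromoethenyl)carbonyl kept in place: 4-ethylphenyl in place of 4-methoxybenzyl gives a 1.5-fold higher number from compound 1 to compound 4 (0.17 log units; within the scatter) and so leaves the number within the scatter. Among these compounds, the earlier tail comparison had been made only on compounds with hydrogen on the aniline nitrogen, where the step was an at least 8.3-fold higher number from compound 2 to compound 3 (0.92 log units; beyond the scatter), and that step rests on a limit rather than a number; this pair gives the first reading of a tail change with the (1-bromoethenyl)carbonyl present, and here a group with an oxygen and a group of carbon only stand level. Nothing measured here gives a cause for this result.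

The exchange alters the link to the ring and the substituent on the phenyl together, so a 4-methoxyphenyl or a 4-ethylbenzyl tail would be needed to read each change alone. As far as these compounds go, it also remains open whether an amine, a carboxylic acid or a longer chain on the tail would leave the number where it stands.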